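Amino for Chloro: an Expected Shift in Growth Inhibition

A few compounds are considered here, and "the series" means these few. Any claim that something is new, unique, unknown or untested is made for them only; others in the source may bear on it.

Of the compounds shown here, three have been tested in a functional assay on NCI-H226 cells (Homo sapiens) for cytotoxicity, read by sulforhodamine B assay, with a stated time of 48 h; on this read-out higher numbers stand for weaker inhibition of growth and lower numbers for stronger inhibition of growth. Compound 1 `Nc1nc(Cl)c2ncn(Cc3ccc(CCl)cc3)c2n1` gives 37200 nM, compound 2 `ClCc1cccc(Cn2cnc3c(Cl)nc(Cl)nc32)c1` gives 10000 nM, and compound 3 `ClCc1ccc(Cn2cnc3c(Cl)nc(Cl)nc32)cc1` gives 9550 nM. Compound 2 and compound 3 are built from the same atoms joined differently; the difference between the two cores is not broken down here, and their values lie within the scatter of each other. Compound 1 arises from compound 3 by the change (amino in place of chloro on an aromatic carbon), a step of a 3.9-fold higher number from compound 3 to compound 1 (0.59 log units; beyond the scatter). Compound 4 `Nc1nc(Cl)c2ncn(Cc3cccc(CCl)c3)c2n1` is not yet measured in this assay; it arises from compound 2 by the same change, (amino in place of chloro on an aromatic carbon), at the same place. Resting on a 3.9-fold higher number from compound 3 to compound 1 (0.59 log units; beyond the scatter), a step of similar size is expected, a 3.8-fold higher number from compound 2 to compound 4 (0.58 log units; beyond the scatter). Compound 4 is therefore estimated to give about 38000 nM in this assay, between 15000 nM and 100000 nM.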

Compound 4, concentration for total growth inhibition: 42700 nM
Compound 4: the middle estimate sits 1.1-fold (0.05 log units) below what was measured; measured number inside the range.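

In this assay the swap of chloro for amino on an aromatic carbon gives a 4.3-fold higher number from compound 2 to compound 4 (0.63 log units; beyond the scatter) and thus again points towards weaker inhibition of growth. The new step agrees with the earlier one: the same change on two cores in this assay, a 3.9-fold higher number (0.59 log units; beyond the scatter) from compound 3 to compound 1 and a 4.3-fold higher number (0.63 log units; beyond the scatter) from compound 2 to compound 4, 1.1-fold (0.04 log units) apart, within the scatter of two such steps. Within the data shown here, this shows that the change carried over between these two cores with much the same size, but with only two pairs in a single cell line, it does not show that the step would hold on any other core.

The compounds shown leave open whether a methylamino, dimethylamino or hydroxyl group at the same place would give a step of similar size. They also leave open what would follow if a methyl or hydroxymethyl group replaced the chloromethyl group.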